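This account rests on a few compounds, and the source may have more. Where it says the series, first, only, none or still open, it means among the compounds named here.

Of the compounds shown here, three built on one shared core have been tested in a functional assay on HOS-TE85 cells (Homo sapiens) for inhibition, read by CCK-8 assay, with a stated time of 72 h; on this read-out lower numbers stand for stronger inhibition and higher numbers for weaker inhibition. Compound 1 `CCOC(=O)c1sc(N2C(=O)CSC2c2cccc(C(=O)NCCCCn3cccn3)c2)nc1C` gives 430 nM in this assay. Compound 2 `CCN1C(=O)CSC1c1cccc(C(=O)NCCCCc2ccccc2)c1` is reported in this assay only as a limit, > 1000 nM, so its true value is not known as a number. Compound 3 `COc1ccccc1N1C(=O)CSC1c1cccc(C(=O)NCCCCN2CCN(C(=O)OC(C)(C)C)CC2)c1` is likewise reported in this assay only as the limit > 1000 nM. Where compound 2 stands is therefore at the weak end of what has been seen: the one plain feature of the numbers is the limit of > 1000 nM in this assay, at which 2 of the 3 values shown sit, and only compound 1 falls short of that limit. Within the data shown here, no two measured compounds differ in a single place, so there is no measured step to lean on.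

Compound 4 `COc1ccc(N2C(=O)CSC2c2cccc(C(=O)NCCCCc3ccccc3)c2)c(OC)c1` is the next compound, and it differs from compound 2 in one place: 2,4-dimethoxyphenyl in place of ethyl on an amide-type nitrogen in a ring. Putting a ring of that kind on the same nitrogen gives no clear signal in the numbers, since compound 1 and compound 3 both carry a ring there and one gives a number while the other does not. The change is therefore expected to be a step that the limit leaves unreadable from compound 2 to compound 4, that is, none beyond the scatter. Compound 4 is expected to give about 1200 nM in this assay, with a range from 400 nM to 3500 nM.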

Compound 4, half-maximal inhibitory concentration: 90.4 nM
For compound 4 the middle estimate is 13-fold (1.12 log units) above the measured one; measured number outside the range, below it.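

In this assay, putting 2,4-dimethoxyphenyl in place of ethyl on the amide-type nitrogen in the five-membered ring gives an at least 11-fold lower number from compound 2 to compound 4 (1.04 log units; beyond the scatter), so the group on this nitrogen can have a large effect on the read-out. The earlier compounds shown here could not show this: compound 1 and compound 3 also carry a ring on this nitrogen, but they differ from compound 2 in more than one place, whereas here everything else in the molecule stays the same. The step is a minimum and not an exact size because compound 2 is itself only a limit: the limit of > 1000 nM in this assay, at which 2 of the 4 values shown sit.

The change brings in a ring and two methoxy groups in a single move, and the compounds shown do not separate their contributions, so it remains open whether an unsubstituted phenyl or a phenyl with one methoxy group would give a similar step. As far as these compounds go, it is also open whether the same swap would have a similar effect with a different group at the end of the amide chain, such as a piperidine or a carboxylic acid.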